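This account rests on a few compounds, and the source may have more. Where it says the series, first, only, none or still open, it means among the compounds named here.

Values in a functional assay on HepG2 cells (Homo sapiens) for antiproliferative activity, read by MTT assay, with a stated time of 48 h (a lower number here means a stronger inhibitor of growth, a higher number a weaker inhibitor of growth), are as follows.

Compound 1 `COC(=O)N1N=C(c2ccccc2)CC1c1cc(OC)c(OC)c(OC)c1` gives 3950 nM
Compound 2 `COC(=O)N1N=C(c2ccccc2)CC1c1ccc(OC)cc1` gives 12000 nM

Compound 2 has the higher of these two numbers, and its gap to compound 1 lies beyond the scatter. Compound 3 `COC(=O)N1N=C(c2ccccc2)CC1c1ccc(OC)c(OC)c1` differs from compound 2 by one change (methoxy in place of hydrogen on an aromatic carbon) with methoxy in place of hydrogen on an aromatic carbon, ortho to a methoxy group and meta to a large group. Going by the values given here, no measured step isolates this change. Set against compound 2, compound 1 carries further methoxy groups and reads 3950 nM in this assay, so a modest fall in the number is expected, perhaps none beyond the scatter. The estimated change is a 1.7-fold lower number from compound 2 to compound 3 (0.23 log units; within the scatter) as an expected step. For compound 3 the expected value is 7000 nM, with an estimated range of 3000 nM to 16000 nM in this assay.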

Compound 3, concentration for 50% growth inhibition: 9150 nM
The estimate for compound 3 lay 1.3-fold (0.12 log units) below the measured number; the measured number falls inside the stated range.
By their numbers in this assay, from the lowest: compound 1; then compounds 3 and 2 (each within the scatter of the next).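

In this assay, methoxy in place of hydrogen at this position, ortho to a methoxy group and meta to a large group, gives a 1.3-fold lower number from compound 2 to compound 3 (0.12 log units; within the scatter) and so by itself does not shift the number beyond the scatter. The reverse kind of change, hydrogen in place of methoxy on an aromatic carbon, gives a 2.3-fold higher number from compound 1 to compound 3 (0.36 log units; beyond the scatter) and is modest but beyond the scatter, so the further methoxy of compound 1 is what separates it from compound 3 in this series. Nothing measured here offers an explanation for either step.

Going by these compounds, whether a hydroxyl group, an ethoxy group or a chlorine atom at this position would read differently from methoxy remains open. So does whether the step from compound 1 to compound 3 would hold on a core carrying another group in place of the methyl ester.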